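The compounds below may be only part of what the source reports. "The series", "measured", "known", "first", "only" and "open" are said of these compounds alone.

Among the measured compounds shown here, in a functional assay on OVCAR-3 cells (Homo sapiens) for inhibition, read by MTT assay, with a stated time of 24 h (a lower number here means a stronger inhibitor, a higher number a weaker inhibitor), compound 2 `CC1(C)[C@H]2CC[C@]1(C)N(Cc1cn(-c3ccccc3C#N)nn1)C(=O)C2` gives 110 nM, the lowest of the three numbers so far, against compound 3 `CC1(C)[C@H]2CC[C@]1(C)N(Cc1cn(-c3ccccc3F)nn1)C(=O)C2` at 300 nM and compound 1 `CC1(C)[C@H]2CC[C@]1(C)N(Cc1cn(-c3ccc(C#N)cc3)nn1)C(=O)C2` at 380 nM. Compound 4 `CC1(C)[C@H]2CC[C@]1(C)N(Cc1cn(-c3cccc(Cl)c3)nn1)C(=O)C2` differs from compound 2 as follows: 3-chlorophenyl in place of 2-cyanophenyl on an aromatic nitrogen. For the measured compounds named here, no measured compound carries 3-chlorophenyl, so the evidence is indirect. Both measured replacements of 2-cyanophenyl gave higher numbers: a 2.7-fold higher number from compound 2 to compound 3 (0.44 log units; beyond the scatter), and, read in reverse, a 3.5-fold lower number from compound 1 to compound 2 (0.54 log units; beyond the scatter). The two replacements themselves sit close together, with a 1.3-fold lower number from compound 1 to compound 3 (0.10 log units; within the scatter). A similar modest rise is therefore expected in this assay, with an estimated 2.3-fold higher number from compound 2 to compound 4 (0.36 log units; beyond the scatter). The expected value for compound 4 is 250 nM, within an estimated range of 100 nM to 600 nM.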

Compound 4, half-maximal inhibitory concentration: 50 nM
Compound 4: the middle estimate sits 5.0-fold (0.70 log units) above what was measured; the measured number lies below the stated range.
By their numbers in this assay, from the lowest: compound 4; then compound 2; then compounds 3 and 1 (each within the scatter of the next).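

The group on the aromatic nitrogen need not carry a nitrile for a low number in this assay: 3-chlorophenyl gives the first step below 2-cyanophenyl (a 2.2-fold lower number from compound 2 to compound 4 (0.34 log units; beyond the scatter)). The gaps to the other two compounds are wider (a 6.0-fold lower number from compound 3 to compound 4 (0.78 log units; beyond the scatter); a 7.6-fold lower number from compound 1 to compound 4 (0.88 log units; beyond the scatter)), so this position spans a larger range than compounds 1 to 3 showed. No measurement at hand accounts for this order. With a single chlorophenyl in the set, the effects of chlorine and its place on the ring cannot be separated. On these data alone, how an amine or a carboxylic acid on the phenyl ring would read also remains open.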